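Swapping an ester for a dioxolane on two cores

A few compounds are considered here, and "the series" means these few. Any claim that something is new, unique, unknown or untested is made for them only; others in the source may bear on it.

Compound 1 `CCOC(=O)Cn1cc(-c2ccc3ccccc3c2)nn1` and compound 2 `CCOC(=O)Cn1cc(-c2ccc(OC)c(OC)c2OC)nn1` both carry an ethoxycarbonyl on a saturated chain carbon bound to an aromatic nitrogen; the difference between their two cores is not broken down here. In a functional assay on B16 cells (Mus musculus) for cytotoxicity, read by MTT assay, with a stated time of 48 h (a lower number here means a stronger inhibitor, a higher number a weaker inhibitor), compound 1 gives only a limit of the assay, > 100000 nM. In this assay compound 2 likewise gives only a limit, > 100000 nM. Compound 3 `CC1(C)OC[C@H](Cn2cc(-c3ccc4ccccc4c3)nn2)O1` gives 12000 nM in this assay. The change 2,2-dimethyl-1,3-dioxolan-4-yl in place of ethoxycarbonyl on a saturated chain carbon bound to an aromatic nitrogen thus brought an at least 8.3-fold lower number from compound 1 to compound 3 (0.92 log units; beyond the scatter), a step that can only be bounded because of the limit of > 100000 nM in this assay, at which 2 of the 3 values shown sit. Compound 4 `COc1ccc(-c2cn(C[C@H]3COC(C)(C)O3)nn2)c(OC)c1OC` differs from compound 2 by the same change, (2,2-dimethyl-1,3-dioxolan-4-yl in place of ethoxycarbonyl on a saturated chain carbon bound to an aromatic nitrogen). A step in the same direction is expected, an at least 3.3-fold lower number from compound 2 to compound 4 (0.52 log units; beyond the scatter), resting on the measured step of an at least 8.3-fold lower number from compound 1 to compound 3 (0.92 log units; beyond the scatter), with wide uncertainty since the cores differ. Compound 4 is expected to give about 30000 nM, somewhere between 8000 nM and 120000 nM.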

Compound 4, half-maximal inhibitory concentration: > 100000 nM
Compound 4: no number, only a limit; the forecaster's own chance of this, stated with the estimate: 40%; at least 3.3-fold (0.52 log units) between middle value and limit.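

No step can be read from compound 2 to compound 4, because both give only a limit: the limit of > 100000 nM in this assay, at which 3 of the 4 values shown sit. From the compounds shown here alone, whether 2,2-dimethyl-1,3-dioxolan-4-yl in place of ethoxycarbonyl lowers the number on the core of compound 2, as on that of compound 1, stays open.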